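This account rests on a few compounds, and the source may have more. Where it says the series, first, only, none or still open, it means among the compounds named here.

Compound 1 `CC(C)c1onc(-c2c(Cl)cccc2Cl)c1COc1ccc(-c2nc3cc(C(=O)O)ccc3n2C)cc1` gives 4410 nM in an assay on HEK-293T cells for antagonist activity at vitamin D3 receptor (Homo sapiens), read by a luciferase reporter, with a stated time of 24 h; a lower number here means a stronger inhibitor, a higher number a weaker inhibitor.
Compound 2 `CCn1c(-c2ccc(OCc3c(-c4c(Cl)cccc4Cl)noc3C(C)C)cc2)nc2ccc(C(=O)O)cc21` gives 5760 nM.
Compound 3 `CC(C)c1onc(-c2c(Cl)cccc2Cl)c1COc1ccc(-c2nc3ccc(C(=O)O)cc3n2CC(C)(C)C)cc1` gives 861 nM.

Compound 2 has the highest number of the three; compound 1 lies within the scatter of it, while compound 3 stands apart, a 6.7-fold lower number from compound 2 to compound 3 (0.83 log units; beyond the scatter). Compound 4 `CC(C)c1onc(-c2c(Cl)cccc2Cl)c1COc1ccc(-c2nc3ccc(C(=O)O)cc3n2C(C)C)cc1` is unmeasured and differs from compound 2 by methyl in place of hydrogen on a saturated chain carbon bound to an aromatic nitrogen and a saturated chain carbon. Among the compounds with values here, the one measured step that bears on this change is a 6.7-fold lower number from compound 2 to compound 3 (0.83 log units; beyond the scatter), in which a larger group at the same position gave the lower number. The present change is smaller, so a step in the same direction but short of that one is expected, probably beyond the scatter. Compound 4 is therefore estimated at 2500 nM, between 1200 nM and 5500 nM, which would mean a 2.3-fold lower number from compound 2 to compound 4 (0.36 log units; beyond the scatter).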

Compound 4, half-maximal inhibitory concentration: 3550 nM
The estimate for compound 4 lay 1.4-fold (0.15 log units) below the measured number; the range from low to high includes it.
By their numbers in this assay, from the lowest: compound 3; then compounds 4, 1 and 2 (each within the scatter of the next).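

In this assay, ethyl to isopropyl on the aromatic nitrogen gives a step that stays within the scatter: a 1.6-fold lower number from compound 2 to compound 4 (0.21 log units; within the scatter). Isopropyl in place of neopentyl on an aromatic nitrogen, by contrast, gives a 4.1-fold higher number from compound 3 to compound 4 (0.62 log units; beyond the scatter), so among the ethyl, isopropyl and neopentyl groups only neopentyl stands apart. Nothing available gives a reason for this difference. From the compounds shown here alone, whether a longer straight chain or a benzyl group on the aromatic nitrogen would stand with neopentyl or with isopropyl remains open, as does the outcome of an amide in place of the carboxylic acid.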